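A few compounds are considered here, and "the series" means these few. Any claim that something is new, unique, unknown or untested is made for them only; others in the source may bear on it.

Compound 1 `O=C1Nc2ccccc2/C1=C/c1ccc(-c2cn(-c3ccccc3Cl)nn2)cc1` sits at a limit of the assay, > 20000 nM. Compound 2 `O=C1Nc2ccccc2/C1=C/c1ccc(-c2cn(-c3cccc(Cl)c3)nn2)cc1` also sits at a limit, > 20000 nM. Compound 3 `O=C1Nc2ccc(F)cc2/C1=C/c1ccc(-c2cn(-c3ccccc3Cl)nn2)cc1` gives 18200 nM.

Among the compounds with values here, in an ADME assay on HUVEC cells (Homo sapiens) for inhibition, read by CCK-8 assay, with a stated time of 24 h, in the presence of a further agent that is not named here (on this read-out higher numbers stand for weaker inhibition and lower numbers for stronger inhibition), compound 3 is the only compound with a number. The change fluoro in place of hydrogen on an aromatic carbon gives an at least 1.0-fold lower number from compound 1 to compound 3 (0.04 log units; that floor lies within the scatter). The change 3-chlorophenyl in place of 2-chlorophenyl on an aromatic nitrogen gives a step that the two limits leave unreadable from compound 1 to compound 2, which cannot be read because of the limit of > 20000 nM in this assay, at which 2 of the 3 values shown sit.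

Compound 4 `O=C1Nc2ccc(F)cc2/C1=C/c1ccc(-c2cn(-c3cccc(Cl)c3)nn2)cc1` has not been measured. It differs from compound 3 by 3-chlorophenyl in place of 2-chlorophenyl on an aromatic nitrogen, the same change as from compound 1 to compound 2, at a place described in the same words. The two cores differ by fluoro in place of hydrogen on an aromatic carbon.

In this assay the step of a 1.2-fold higher number from compound 3 to compound 4 (0.08 log units; within the scatter) is expected, resting on the unreadable a step that the two limits leave unreadable from compound 1 to compound 2 and on compound 3 at 18200 nM. Compound 4 is therefore estimated at 22000 nM, between 9000 nM and 60000 nM, most likely reported as a limit.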

Compound 4, half-maximal inhibitory concentration: 19400 nM
Compound 4: middle estimate off by 1.1-fold (0.05 log units), on the high side, within the range that was stated.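

In this assay, the 3-chlorophenyl change on the fluoro core gives a 1.1-fold higher number from compound 3 to compound 4 (0.03 log units; within the scatter), so the change that could not be read on the core of compound 1 has a readable size here. The fluoro change gives an at least 1.0-fold lower number from compound 2 to compound 4 (0.01 log units; that floor lies within the scatter), and this floor can be set beside the earlier one only with a caveat: the same change on two cores in this assay, an at least 1.0-fold lower number (0.04 log units; that floor lies within the scatter) from compound 1 to compound 3 and an at least 1.0-fold lower number (0.01 log units; that floor lies within the scatter) from compound 2 to compound 4; the limit leaves it open whether they differ. The data therefore do not show whether either change carries over unaltered from one core to the other, and the chlorophenyl step without fluoro remains unreadable: the limit of > 20000 nM in this assay, at which 2 of the 4 values shown sit.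

The compounds shown leave open how a methoxy group or an amine in place of the chlorine would read in this assay. They also leave open what a carboxylic acid in place of the fluoro group would give.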